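From Compound 1 to Compound 4: Exchanging One Nitrogen Substituent

This account rests on a few compounds, and the source may have more. Where it says the series, first, only, none or still open, it means among the compounds named here.

In a functional assay on Ishikawa cells (Homo sapiens) for antiproliferative activity, read by CCK-8 assay, with a stated time of 48 h (a higher number here means a weaker inhibitor, a lower number a stronger inhibitor), compound 1 `O=C(/C=C/CN1CC(Oc2ccc(Oc3c(-c4ccc(F)cc4)sc4cc(O)ccc34)cc2)C1)N1CCCC1` gives 9150 nM. Compound 2 `O=C(/C=C/CNCCOc1ccc(Oc2c(-c3ccc(F)cc3)sc3cc(O)ccc23)cc1)N1CCC1` gives 6560 nM, and compound 3 `C=CC(=O)N1CC(Oc2ccc(Oc3c(-c4ccc(F)cc4)sc4cc(O)ccc34)cc2)C1` gives 12300 nM. These three values all lie within the usual scatter of one another, so compound 1 cannot be ranked apart from the other two.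

Compound 4 `C=C(C)C(=O)N1CC(Oc2ccc(Oc3c(-c4ccc(F)cc4)sc4cc(O)ccc34)cc2)C1` has not yet been measured. Its difference from compound 1 is (1-methylethenyl)carbonyl in place of 3-((pyrrolidin-1-yl)carbonyl)prop-2-en-1-yl on an amine nitrogen in a ring. The closest measured comparison is a 1.3-fold higher number from compound 1 to compound 3 (0.13 log units; within the scatter). That step also replaces the side chain on an amine nitrogen in a ring, and compound 3 carries vinylcarbonyl where compound 4 carries (1-methylethenyl)carbonyl. The other relevant comparison is a 1.9-fold higher number from compound 2 to compound 3 (0.27 log units; within the scatter). Since neither step goes beyond the scatter, no real shift is expected in this assay. The expected step is a 1.3-fold higher number from compound 1 to compound 4 (0.12 log units; within the scatter). Compound 4 is estimated at 12000 nM, with an expected range of 6000 nM to 24000 nM.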

Compound 4, half-maximal inhibitory concentration: 14200 nM
Compound 4: middle estimate off by 1.2-fold (0.07 log units), on the low side, and the stated range covers the measured number.
By their numbers in this assay, from the lowest: compounds 2, 1, 3 and 4 (each within the scatter of the next, the first and the last beyond it).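

In this assay, methyl in place of hydrogen on a double-bonded chain carbon bound to a carbonyl carbon leaves the number within the scatter (a 1.2-fold higher number from compound 3 to compound 4 (0.06 log units; within the scatter)), and so does the larger exchange on the amine nitrogen in the ring (a 1.6-fold higher number from compound 1 to compound 4 (0.19 log units; within the scatter)). Going by these compounds alone, the one step beyond the scatter is modest (a 2.2-fold higher number from compound 2 to compound 4 (0.34 log units; beyond the scatter)). It exchanges a whole group on an oxygen on an aromatic ring, and it cannot be tied to any single feature of that group. Nothing shown here gives a reason for these numbers.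

On these data alone, whether a larger group at the methyl position, such as an ethyl or a longer chain, would also stay within the scatter remains open. So does the effect of an amine or a carboxylic acid there.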